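Urea and amide variants on a shared trifluoromethyl-pyridine core

The source may report more compounds than this note shows. Statements on the series, on what has been measured and on what is new or still open speak of the compounds shown alone.

Measured so far:
compound 1 `CC1CCN(c2nc(C(F)(F)F)ccc2CNC(=O)C(C)c2ccc(CNS(C)(=O)=O)c(F)c2)CC1` — 27.6 nM
compound 2 `CC1CCN(c2nc(C(F)(F)F)ccc2CNC(=O)Nc2ccc(NS(C)(=O)=O)c(F)c2)CC1` — 149 nM
compound 3 `CC1CCN(c2nc(C(F)(F)F)ccc2CNC(=O)NCc2ccc(CNS(C)(=O)=O)c(F)c2)CC1` — 199 nM

Of the compounds shown here, three share the core of compound 1 and have been tested in an assay on CHO cells for antagonist activity at transient receptor potential cation channel subfamily V member 1 (Homo sapiens), read by scintillation counting, with a stated time of 5 min; a higher number here means a weaker inhibitor, a lower number a stronger inhibitor. Compound 1, the amide, gives 27.6 nM. Compound 2, the aryl urea, gives 149 nM and stands second highest of the three numbers; compound 3, the benzyl urea, gives 199 nM, and the two ureas lie within the scatter of each other, so no order between them is claimed. Compound 1 sits clearly lower than compound 2, beyond the scatter.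

Compound 4 `CC1CCN(c2nc(C(F)(F)F)ccc2CNC(=O)N(C)c2ccc(NS(C)(=O)=O)c(F)c2)CC1` has not been measured. It differs from compound 2 in one place: methyl in place of hydrogen on an amide-type nitrogen whose other neighbours are an aromatic carbon and a carbonyl carbon. Among the measured compounds shown here, no measured pair shows a step of this kind, so the expectation rests on compound 2 alone. The step from compound 2 to compound 4 is expected to be a weakening one, a 2.7-fold higher number from compound 2 to compound 4 (0.43 log units; beyond the scatter), beyond the scatter but not large. Compound 4 is therefore estimated at 400 nM, with a range from 120 nM to 1500 nM, in this assay.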

Compound 4, inhibition constant: 59 nM
The estimate for compound 4 lay 6.8-fold (0.83 log units) above the measured number, outside the stated range (below it).
By their numbers in this assay, from the lowest: compound 1; then compound 4; then compounds 2 and 3 (each within the scatter of the next).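

In this assay, among the compounds shown here, methyl in place of hydrogen on an amide-type nitrogen whose other neighbours are an aromatic carbon and a carbonyl carbon gives a 2.5-fold lower number from compound 2 to compound 4 (0.40 log units; beyond the scatter) and is a modest strengthening, the only single-place step so far. This position therefore accepts a methyl in the aryl urea, and the hydrogen on this nitrogen is not needed for the inhibition read here. No measurement shown accounts for the gain, and the step stands as an observation only.

As far as these compounds go, it remains open whether an ethyl group, a longer chain or a cyclopropyl ring on this nitrogen would hold or extend the step. From the compounds shown here alone, it is also open whether methyl on the corresponding urea nitrogen of the benzyl urea, compound 3, would move the number the same way.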